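The source may hold more compounds than are shown below. What is called first, only, known or untested is meant among the compounds shown, and "the series" means these compounds.

Measured compounds:
compound 1, `CCCCCCCCCCCO[C@@H]1[C@@H](O)[C@H](O[C@H]2O[C@H](CN)[C@@H](O)[C@H](O)[C@H]2N)[C@@H](N)C[C@H]1N`, gives 74.7%
compound 2, `CCCCCCCO[C@@H]1[C@@H](O)[C@H](O[C@H]2O[C@H](CN)[C@@H](O)[C@H](O)[C@H]2N)[C@@H](N)C[C@H]1N`, gives 84.3%
compound 3, `CCCCCCCCCCCO[C@@H]1[C@@H](O)[C@H](O[C@H]2O[C@H](CN)[C@@H](O)[C@H](OCCCCCCC)[C@H]2N)[C@@H](N)C[C@H]1N`, gives 82.9%

These values come from an ADME assay on J774 cells (Mus musculus) for cytotoxicity, read by MTT assay, with a stated time of 24 h, tested at 10 uM; a lower number here means a stronger effect, a higher number a weaker effect of the compound at the concentration tested. Compound 4, `CCCCCCCCCCCO[C@@H]1[C@@H](N)[C@@H](O[C@H]2[C@H](O)[C@@H](OCCCCCCCCCCC)[C@H](N)C[C@@H]2N)O[C@H](CN)[C@H]1O`, has not been measured there yet. Compound 4 arises from compound 3 by butyl in place of hydrogen on a saturated chain carbon, seven bonds along the chain from an oxygen on a saturated carbon. The same change, (butyl in place of hydrogen on a saturated chain carbon, seven bonds along the chain from an oxygen on a saturated carbon), turns compound 2 into compound 1, where it gave a number 9.6 percentage points lower from compound 2 to compound 1 (within the scatter). The difference between the core of compound 2 and the core of compound 3 is not broken down here. That earlier step lay within the scatter, so no marked shift is anticipated for the new pair. For compound 4 a step of similar size is expected, a number 7.9 percentage points lower from compound 3 to compound 4 (within the scatter). Among the measured compounds shown here, this expectation rests on the one earlier case a number 9.6 percentage points lower from compound 2 to compound 1 (within the scatter) and on compound 3 giving 82.9%. Compound 4 is therefore estimated at 75%, within a range from 60% to 90%.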

Compound 4, a percentage reported as activity, at one concentration (the size of the read-out at that concentration, not a potency): 81.7%
Compound 4: middle estimate off by 6.7 percentage points, on the low side; the measured number falls inside the stated range.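

Butyl at this place on the chain gives a number 1.2 percentage points lower from compound 3 to compound 4 (within the scatter) in this assay, and the two cases of this change do not differ: the same change on two cores in this assay, a number 9.6 percentage points lower (within the scatter) from compound 2 to compound 1 and a number 1.2 percentage points lower (within the scatter) from compound 3 to compound 4, 8.4 percentage points apart, within the scatter of two such steps. Undecyl on the oxygen likewise gives a number 7 percentage points higher from compound 1 to compound 4 (within the scatter). The change therefore reads the same on these two cores, but with every step within the scatter, this does not show that it has any effect of its own, nor how it would behave on a third core.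

The compounds shown leave open whether a chain longer than undecyl, or one ending in an amine or a carboxylic acid, would give a step beyond the scatter. They also leave open how these compounds would read at any other concentration.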